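A Fluoro for Methyl Step on a Thiourea Acid

The compounds below may be only part of what the source reports. "The series", "measured", "known", "first", "only" and "open" are said of these compounds alone.

Compound 1, `O=C(O)CCC1=C(c2ccccc2)NC(=S)NC1c1ccco1`, gives 21.8% in a functional assay on the whole organism (strain Albino) for inhibition, with Rattus norvegicus as the target, with stated times of 1 h and 2 h, at a dose of 20 mg/kg by the oral route; a lower number here means less inhibition, a higher number more inhibition at the dose given (going by the name of the read-out).
Compound 2, `Cc1ccc(C2=C(CCC(=O)O)C(c3ccco3)NC(=S)N2)cc1`, gives 28.1% in this assay.

Compound 2 has the higher of the two numbers, but its step from compound 1, a number 6.3 percentage points higher from compound 1 to compound 2 (within the scatter), lies within the scatter. Compound 3, `O=C(O)CCC1=C(c2ccc(F)cc2)NC(=S)NC1c1ccco1`, differs from compound 2 by fluoro in place of methyl on an aromatic carbon; read one bond further out, 4-methylphenyl becomes 4-fluorophenyl. Within the data shown here, the only step bearing on this place is the one from compound 1 to compound 2, which was within the scatter, so compound 3 is expected to differ little, a number 3.1 percentage points lower from compound 2 to compound 3 (within the scatter). Compound 3 is estimated at 25%, between 12% and 38%.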

Compound 3, a percentage reported as inhibition, in the whole organism at one dose (the size of the read-out at that dose, not a potency): 14.2%
The estimate for compound 3 lay 10.8 percentage points above the measured number; measured number inside the range.
By their numbers in this assay, from the lowest: compounds 3, 1 and 2 (each within the scatter of the next, the first and the last beyond it).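

On the aromatic ring, the change from 4-methylphenyl to 4-fluorophenyl gives the only step beyond the scatter among these compounds in this assay, a number 13.9 percentage points lower from compound 2 to compound 3 (beyond the scatter). Fluoro in place of hydrogen at the same place gives a step within the scatter, a number 7.6 percentage points lower from compound 1 to compound 3 (within the scatter), so this position separates methyl from fluoro, while neither group stands clear of hydrogen. Nothing at hand explains the gap between these two groups.

As far as these compounds go, whether chloro or methoxy at this place would read closer to methyl or to fluoro stays open. So does what an amide in place of the carboxylic acid would give.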